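The source may hold more compounds than are shown below. What is called first, only, known or untested is meant among the compounds shown, and "the series" means these compounds.

The read-out here is a functional assay on MCF7 cells (Homo sapiens) for cytotoxicity, read by MTT assay, with a stated time of 72 h; on this read-out lower numbers stand for stronger inhibition and higher numbers for weaker inhibition. Two compounds carry a known number. Compound 1, `O=C(N/N=C/c1ccc(O)c(Br)c1)Nc1cc2c(Nc3ccc(F)c(Cl)c3)ncnc2cc1O[C@H]1CCOC1`, gives 2690 nM in this assay. Compound 2, `COc1cc2ncnc(Nc3ccc(F)c(Cl)c3)c2cc1NC(=O)N/N=C/c1ccc(F)cc1`, gives 35100 nM in this assay, the higher of the two numbers, so on this read-out compound 2 is the weaker of the pair and compound 1 the stronger, with a gap between them that the two values show to be beyond the usual scatter.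

Compound 3, `CCN(CC)c1ccc(/C=N/NC(=O)Nc2cc3c(Nc4ccc(F)c(Cl)c4)ncnc3cc2OC)c(O)c1`, has not been measured yet. It differs from compound 2 in a single place: 4-(diethylamino)-2-hydroxyphenyl in place of 4-fluorophenyl on a carbon with a double bond to nitrogen. The ring that leaves carries no hydrogen-bond donor or acceptor; the ring that enters brings one donor and two acceptors. For the measured compounds named here, no measured pair here tracks this exact change, so the expectation rests only on the two known values.

For compound 3 a lower number than for compound 2 is expected, and the step from compound 2 to compound 3 is estimated at a 3.9-fold lower number from compound 2 to compound 3 (0.59 log units; beyond the scatter), a shift that would be beyond the scatter but would still leave compound 3 short of compound 1. The estimate for compound 3 in this assay is 9000 nM, with a range from 2500 nM to 30000 nM.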

Compound 3, half-maximal inhibitory concentration: 27300 nM
Beside the measured number, compound 3's estimate is 3.0-fold (0.48 log units) below it; the measured number falls inside the stated range.
By their numbers in this assay, from the lowest: compound 1; then compounds 3 and 2 (each within the scatter of the next).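

In this assay, putting 4-(diethylamino)-2-hydroxyphenyl in place of 4-fluorophenyl on the carbon with a double bond to nitrogen gives a 1.3-fold lower number from compound 2 to compound 3 (0.11 log units; within the scatter), so compound 2 and compound 3 cannot be told apart on this read-out. This place therefore accepts a clearly bigger ring substituent, with 12 heavy atoms entering where 7 leave and with a hydrogen-bond donor and acceptors where the leaving group has none, and no change beyond the scatter appears in this cytotoxicity number. No independent measurement is available to explain this result.

Since the diethylamino and hydroxy groups enter together, their separate contributions cannot be read from these values, and they might pull in opposite directions or each have little effect. From the compounds shown here alone, it also remains open whether a different group on this ring, such as a carboxylic acid or a morpholine, would move the number beyond the scatter, and whether this same swap would leave the number just as unmoved on compound 1.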